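Swapping methoxy for fluoro on a second oxime core

The source may report more compounds than this note shows. Statements on the series, on what has been measured and on what is new or still open speak of the compounds shown alone.

Of the compounds shown here, three have been measured in a functional assay (Mus musculus, strain Balb/c) for inhibition, read by ELISA, with a stated time of 72 h; a lower number here means a stronger inhibitor, a higher number a weaker inhibitor. Compound 2 `COc1ccc(/C=C/C(=N\O)c2ccc(Cl)cc2)cc1` gives 5850 nM. Compound 1 `O/N=C(\C=C\c1ccc(F)cc1)c1ccc(Cl)cc1` gives 10600 nM, and compound 3 `COc1ccc(/C=C/C(=N\O)c2ccc(C)cc2)cc1` gives 6240 nM. The shared starting point for the comparisons is compound 2. Changing it to compound 1 is described as fluoro in place of methoxy on an aromatic carbon, and that change produced a 1.8-fold higher number from compound 2 to compound 1 (0.26 log units; within the scatter). Changing it to compound 3 is described as methyl in place of chloro on an aromatic carbon, which produced a 1.1-fold higher number from compound 2 to compound 3 (0.03 log units; within the scatter). Compound 3 therefore sits close to compound 2 in this assay, and both differences are small enough that no ordering between the three can be claimed.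

Compound 4 `Cc1ccc(C(/C=C/c2ccc(F)cc2)=N/O)cc1` has not yet been measured. Its core is that of compound 3, and the difference between the two cores is the one given above as methyl in place of chloro on an aromatic carbon. The change from compound 3 to compound 4 is fluoro in place of methoxy on an aromatic carbon. The place of this change is described in the same words as the place of the change from compound 2 to compound 1, so it is the same change, now made on the methyl-bearing core. Because the earlier step was a 1.8-fold higher number from compound 2 to compound 1 (0.26 log units; within the scatter), the step from compound 3 to compound 4 is expected to be of similar size, about a 1.8-fold higher number from compound 3 to compound 4 (0.25 log units; within the scatter). On that basis compound 4 is estimated at 11000 nM, with a range from 5000 nM to 25000 nM, resting on one earlier example only.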

Compound 4, half-maximal inhibitory concentration: 11300 nM
Compound 4: the middle estimate sits 1.0-fold (0.01 log units) below what was measured, and the stated range covers the measured number.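

In this assay, putting fluoro in place of methoxy on an aromatic carbon of the core of compound 3 gives a 1.8-fold higher number from compound 3 to compound 4 (0.26 log units; within the scatter) and this step matches the same change made on the core of compound 2: the same change on two cores in this assay, a 1.8-fold higher number (0.26 log units; within the scatter) from compound 2 to compound 1 and a 1.8-fold higher number (0.26 log units; within the scatter) from compound 3 to compound 4, 1.0-fold (0.00 log units) apart, within the scatter of two such steps. The second change in the set, methyl in place of chloro on an aromatic carbon, gives a 1.1-fold higher number from compound 1 to compound 4 (0.03 log units; within the scatter) and it too matches its earlier counterpart: the same change on two cores in this assay, a 1.1-fold higher number (0.03 log units; within the scatter) from compound 2 to compound 3 and a 1.1-fold higher number (0.03 log units; within the scatter) from compound 1 to compound 4, 1.0-fold (0.00 log units) apart, within the scatter of two such steps. Across these four compounds, each change therefore came out the same size on both cores, which fits the two changes acting independently of each other, but every step lies within the scatter, so this does not show that either change has a real effect on inhibition, and two pairs cannot show that the match would hold on other cores.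

The compounds shown carry only fluoro or methoxy at one end and only chloro or methyl at the other, so it stays open whether a step beyond the scatter could be reached in these places. An amine, a carboxylic acid or a nitrile at either end would test this, and would also show whether a larger step carries between cores as evenly as these small ones do.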